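Fluoro to hydrogen: compound 3 to compound 4

The compounds below may be only part of what the source reports. "The series", "measured", "known", "first", "only" and "open" are said of these compounds alone.

Values in an ADME assay on liver for metabolic stability, with Liver microsome (Homo sapiens) as the target, read by LC-MS, using microsomes; on this read-out higher numbers stand for fast clearance and lower numbers for slow clearance:
- compound 1 `COC(C)(C)[C@@H](O)C(=O)N1C[C@H]2C[C@H]2[C@H]1C(=O)NCc1cc(Cl)ccc1-n1cnnn1`: 23 mL.min-1.g-1
- compound 2 `CC1(C[C@@H](O)C(=O)N2C[C@H]3C[C@H]3[C@H]2C(=O)NCc2cc(Cl)ccc2-n2cnnn2)CC1`: 12 mL.min-1.g-1
- compound 3 `O=C(NCc1cc(Cl)ccc1-n1cnnn1)[C@@H]1[C@@H]2C[C@@H]2CN1C(=O)[C@H](O)c1ccccc1F`: < 12 mL.min-1.g-1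
- compound 4 `O=C(NCc1cc(Cl)ccc1-n1cnnn1)[C@@H]1[C@@H]2C[C@@H]2CN1C(=O)[C@H](O)c1ccccc1`: not yet measured

Compound 3 stands at < 12 mL.min-1.g-1, which is a limit of the assay and not a number. Compound 4 carries hydrogen in place of fluoro on an aromatic carbon, ortho to a large group: hydrogen in place of fluoro on an aromatic carbon. Within the data shown here, no measured step changes this fluoro alone. The nearest steps replace the whole group on the chain carbon: a 1.9-fold lower number from compound 1 to compound 2 (0.28 log units; within the scatter), an at least 1.9-fold lower number from compound 1 to compound 3 (0.28 log units; that floor lies within the scatter) and a number no higher from compound 2 to compound 3 (the limit leaves the size open). None of these shows a readable size beyond the scatter, so no step beyond the scatter is expected in this assay, in either direction. The expected step is a number no lower from compound 3 to compound 4 (the limit leaves the size open). For compound 4 the estimate is 12 mL.min-1.g-1, with an expected range of 7 mL.min-1.g-1 to 22 mL.min-1.g-1.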

Compound 4, intrinsic clearance in microsomes: < 15 mL.min-1.g-1
Compound 4: a limit, no number; the forecaster's own chance of this, stated with the estimate: 50%; the middle value is on the limit's open side.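

In this assay, hydrogen in place of fluoro on this aromatic carbon, ortho to a large group, still gives no number: compound 4 also stands at a limit of the assay, so the fluoro is not needed to stay out of the readable range. Phenyl in place of 1-methoxy-1-methylethyl gives an at least 1.5-fold lower number from compound 1 to compound 4 (0.18 log units; that floor lies within the scatter). The steps to compound 4 from compound 2 and compound 3 cannot be read.

On these data alone, the true clearance of compound 3 and compound 4 stays open. So does whether chloro or methoxy in the same place would give a readable number.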